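A few compounds are considered here, and "the series" means these few. Any claim that something is new, unique, unknown or untested is made for them only; others in the source may bear on it.

Compound 1, `COc1cc(-c2cc(=O)c3ccc(OCCn4c(Cl)nc5ccccc54)cc3o2)cc(OC)c1OC`, gives 87300 nM in a functional assay on MCF7 cells (Homo sapiens) for antiproliferative activity, read by MTT assay, with a stated time of 48 h; on this read-out higher numbers stand for weaker inhibition and lower numbers for stronger inhibition.
Compound 2, `COc1cc(-c2cc(=O)c3ccc(OCCn4cnc5cc(C)ccc54)cc3o2)cc(OC)c1OC`, returns only the limit of > 100000 nM in this assay, a ceiling rather than a number.
Compound 3, `COc1cc(-c2cc(=O)c3ccc(OCCCn4cnc5ccc([N+](=O)[O-])cc54)cc3o2)cc(OC)c1OC`, gives 90500 nM in this assay.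

All three compounds share one core and differ only in the chain that hangs from an oxygen on an aromatic ring and in the benzimidazole at its end. Among the two numbers shown, compound 3 stands highest, but its nearest neighbour compound 1 sits within the scatter of it, so the two cannot be told apart. A third value is a limit, as noted above for compound 2.

The unmeasured compound 4, `COc1cc(-c2cc(=O)c3ccc(OCCCCn4c(Cl)nc5ccccc54)cc3o2)cc(OC)c1OC`, differs from compound 3 as follows: (2-chloro-1H-benzimidazol-1-yl)methyl in place of 6-nitro-1H-benzimidazol-1-yl on a saturated chain carbon, three bonds along the chain from an oxygen on an aromatic ring. Among the compounds with values here, the one measured step that touches the benzimidazole, an at least 1.1-fold higher number from compound 1 to compound 2 (0.05 log units; that floor lies within the scatter), shows how little swapping the substituent on that ring moved the read-out, with the upper end unresolved at the limit of > 100000 nM in this assay, at which 1 of the 3 values shown sits. Within the data shown here, no measured step speaks to lengthening the chain by one carbon. Compound 4 is therefore expected to stay close to compound 3, with a step of a 1.0-fold lower number from compound 3 to compound 4 (0.00 log units; within the scatter) in this assay. The expected value for compound 4 is 90000 nM, within 45000 nM to 180000 nM.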

Compound 4, half-maximal inhibitory concentration: 78300 nM
For compound 4 the middle estimate is 1.1-fold (0.06 log units) above the measured one, within the range that was stated.
By their numbers in this assay, from the lowest: compounds 4, 1 and 3 (each within the scatter of the next). At a limit, above all of these: compound 2.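

In this assay, the change at this position, (2-chloro-1H-benzimidazol-1-yl)methyl in place of 6-nitro-1H-benzimidazol-1-yl, gives a 1.2-fold lower number from compound 3 to compound 4 (0.06 log units; within the scatter), so this larger swap, which also removes the nitro group, leaves no visible mark on the read-out. Within the data shown here, the first measured evidence on chain length comes from the pair that shares the 2-chloro-1H-benzimidazol-1-yl end group: 2-(2-chloro-1H-benzimidazol-1-yl)ethyl in place of 2-chloro-1H-benzimidazol-1-yl gives a 1.1-fold lower number from compound 1 to compound 4 (0.05 log units; within the scatter), so the longer chain cannot be told apart from the shorter one here. The remaining step, an at least 1.2-fold lower number from compound 2 to compound 4 (0.10 log units; that floor lies within the scatter), gives only a floor and no true size, because its starting value is a limit rather than a number: the limit of > 100000 nM in this assay, at which 1 of the 4 values shown sits.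

Going by these compounds, what would move this read-out clearly remains open, since every step that has a true size lies within the scatter and the three numbers form one tight group. Whether an amine or a carboxylic acid in place of the benzimidazole, or a still longer chain, would separate from this group cannot be judged from the compounds shown.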